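Replacing 3-(methylsulfanyl)propyl with 2-fluorophenyl: expected cell tolerance

The compounds below may be only part of what the source reports. "The series", "measured", "known", "first", "only" and "open" are said of these compounds alone.

Compound 1 `CCNC(=S)Nc1cccc(C(F)(F)F)c1`: > 100000 nM (a limit)
Compound 2 `Fc1ccc(NC(=S)Nc2cccc(C(F)(F)F)c2)cc1`: 40000 nM
Compound 3 `CSCCCNC(=S)Nc1cccc(C(F)(F)F)c1`: > 100000 nM (a limit)

In an ADME assay on Vero 76 cells (Chlorocebus sabaeus) for cytotoxicity, read by crystal violet staining, with a stated time of 96 h (a lower number here means that less compound is tolerated, a higher number that more compound is tolerated), compound 3 gives > 100000 nM, which is a limit and not a number. Compound 3 shares the limit of > 100000 nM in this assay, at which 2 of the 3 values shown sit, with compound 1.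

Compound 4 `Fc1ccccc1NC(=S)Nc1cccc(C(F)(F)F)c1` has not yet been measured. It differs from compound 3 by a single change, 2-fluorophenyl in place of 3-(methylsulfanyl)propyl on an amide-type nitrogen.

The nearest measured evidence is an at least 2.5-fold higher number from compound 2 to compound 3 (0.39 log units; beyond the scatter), where 3-(methylsulfanyl)propyl replaces 4-fluorophenyl on an amide-type nitrogen. Running that change the other way, with a fluorophenyl group entering, suggests a lower number. The step of an at least 2.5-fold lower number from compound 1 to compound 2 (0.39 log units; beyond the scatter), with 4-fluorophenyl in place of ethyl, points the same way. The remaining step, a step that the two limits leave unreadable from compound 1 to compound 3, gives no size.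

Within the data shown here, compound 4 carries 2-fluorophenyl rather than the 4-fluorophenyl of compound 2, and no measured pair compares the two. Even so, compound 2 at 40000 nM is the best guide, so a modest or larger fall is expected in this assay. The expected change is an at least 2.5-fold lower number from compound 3 to compound 4 (0.39 log units; beyond the scatter). Compound 4 is estimated at 40000 nM, with an expected range from 15000 nM to 100000 nM.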

Compound 4, half-maximal cytotoxic concentration: 64000 nM
Compound 4: the middle estimate sits 1.6-fold (0.20 log units) below what was measured, and the stated range covers the measured number.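

Exchanging 4-fluorophenyl for 2-fluorophenyl on the amide-type nitrogen gives a 1.6-fold higher number from compound 2 to compound 4 (0.20 log units; within the scatter) in this assay, so the two fluorophenyl groups are not told apart here. Against the chains the picture is less firm than compound 2 alone suggested: 2-fluorophenyl in place of 3-(methylsulfanyl)propyl gives an at least 1.5-fold lower number from compound 3 to compound 4 (0.19 log units; that floor lies within the scatter), and 2-fluorophenyl in place of ethyl gives an at least 1.5-fold lower number from compound 1 to compound 4 (0.19 log units; that floor lies within the scatter), so compound 4 by itself does not establish a drop from either chain compound. Going by these compounds, compound 1 and compound 3 each carry a limit and not a number, and the full size of both steps stays open at that end: the limit of > 100000 nM in this assay, at which 2 of the 4 values shown sit.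

On these data alone, it remains open whether an unsubstituted phenyl, a 3-fluorophenyl or a 2-chlorophenyl on the same nitrogen would read alongside compound 2 and compound 4, or would separate from them beyond the scatter. As far as these compounds go, it is equally open whether a longer chain, or a chain ending in an amine or a carboxylic acid, would stay at the limit shared by compound 1 and compound 3.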